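Methyl for hydrogen on the benzyl group: cytotoxicity outlook

The source may hold more compounds than are shown below. What is called first, only, known or untested is meant among the compounds shown, and "the series" means these compounds.

Compound 2 `c1ccc(Cn2ccc3nc(-c4ccccc4)nc-3c2)cc1` stands at a limit rather than a number: in an ADME assay on MDBK cells (Bos taurus) for cytotoxicity (a higher number here means that more compound is tolerated, a lower number that less compound is tolerated), compound 2 gives > 100000 nM, which is a limit of the assay. Compound 1 `Fc1cccc(F)c1-c1nc2ccn(Cc3ccccc3)cc-2n1` likewise rests at a limit; in this assay compound 1 gives > 100000 nM. The step that the two limits leave unreadable from compound 1 to compound 2 is therefore unreadable in size and direction, and the limit of > 100000 nM in this assay, at which 2 of the 2 values shown sit, records where both values sit. Compound 3 `Cc1ccc(Cn2ccc3nc(-c4ccccc4)nc-3c2)cc1` differs from compound 2 by methyl in place of hydrogen on an aromatic carbon. Going by the values given here, no measured step bears directly on this change, and the single step gives no readable size, so no direction beyond the scatter can be expected from it. Compound 3 is therefore expected to remain at the same limit, with the step from compound 2 to compound 3 estimated as a number no higher from compound 2 to compound 3 (the limit leaves the size open). The estimate for compound 3 in this assay is 100000 nM, with a range from 50000 nM to 200000 nM.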

Compound 3, half-maximal cytotoxic concentration: > 100000 nM
Compound 3 gave a limit, no number (the forecaster's own chance of this, stated with the estimate: 85%); the middle value lies on the limit itself.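

Compound 2 and compound 3 both rest at a limit in this assay, so the step between them cannot be read in size or direction: the limit of > 100000 nM in this assay, at which 3 of the 3 values shown sit.

The compounds shown leave open at what concentration any of them becomes cytotoxic, and whether the methyl group changes that concentration.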